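Chloro for methyl on the benzyl ring of compound 3

This account rests on a few compounds, and the source may have more. Where it says the series, first, only, none or still open, it means among the compounds named here.

Compound 1, `CC(C)(C)[C@H]1C(O)=C(C2=C(C(N)=O)S(=O)(=O)c3cc(NS(C)(=O)=O)ccc3N2)C(=O)N1Cc1ccc(F)cc1`: 5 mL/min/kg
Compound 2, `CC(C)(C)[C@H]1C(O)=C(C2=CS(=O)(=O)c3cc(NS(C)(=O)=O)cc(F)c3N2)C(=O)N1Cc1ccc(F)cc1`: 36 mL/min/kg
Compound 3, `Cc1cc(CN2C(=O)C(C3=CS(=O)(=O)c4cc(NS(C)(=O)=O)ccc4N3)=C(O)[C@@H]2C(C)(C)C)ccc1F`: 101 mL/min/kg

Of the compounds shown here, three sharing one core have been measured in an in vivo ADME assay on the whole organism for pharmacokinetics, with Rattus norvegicus as the target, at a dose of 2 mg/kg by the intravenous route; a higher number here means faster removal of the compound, a lower number slower removal. Compound 1 gives 5 mL/min/kg, compound 2 gives 36 mL/min/kg and compound 3 gives 101 mL/min/kg. Compound 3 stands highest of the three numbers; its nearest neighbour is compound 2, below it by more than the usual scatter, and compound 1 lies further below it still.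

Compound 4, `CC(C)(C)[C@H]1C(O)=C(C2=CS(=O)(=O)c3cc(NS(C)(=O)=O)ccc3N2)C(=O)N1Cc1ccc(F)c(Cl)c1`, has not yet been measured. It differs from compound 3 in one place: chloro in place of methyl on an aromatic carbon. Among the compounds with values here, no pair differing in exactly one place has been measured here, so no measured step guides the size of this change.

The account expects compound 4 to sit somewhat below compound 3 in this assay, a step of a 1.7-fold lower number from compound 3 to compound 4 (0.23 log units; within the scatter), small enough that it may fall within the scatter, with the present value of compound 3 at 101 mL/min/kg as the anchor. Compound 4 is therefore estimated at 60 mL/min/kg, with a range from 30 mL/min/kg to 120 mL/min/kg.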

Compound 4, clearance: 86 mL/min/kg
Compound 4: middle estimate off by 1.4-fold (0.16 log units), on the low side; the measured number falls inside the stated range.
By their numbers in this assay, from the lowest: compound 1; then compound 2; then compounds 4 and 3 (each within the scatter of the next).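

In this assay, chloro in place of methyl on this aromatic carbon, ortho to a fluoro group, gives a 1.2-fold lower number from compound 3 to compound 4 (0.07 log units; within the scatter), so the two groups cannot be told apart at this position in this read-out. Within the data shown here, this is the only pair here that differs in one place, and it offers a direct reading of one change, which the earlier compounds could not give. Nothing available here explains why the two groups read alike.

On these data alone, it remains open whether a quite different group at this position, such as a methoxy, a nitrile or a primary amine, would also read like methyl and chloro. As far as these compounds go, it is also open whether the same exchange would read alike on the core of compound 1, which carries a carboxamide.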